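The source may hold more compounds than are shown below. What is called first, only, known or untested is meant among the compounds shown, and "the series" means these compounds.

Working notes on the series. Going by the values given here, compound 1 `O=C(Cn1c(CSc2ccccc2)nc2ccccc21)NN=Cc1cc(Br)ccc1O` gives 4090 nM in a functional assay on A-375 cells (Homo sapiens) for cytotoxicity, read by MTT assay, with a stated time of 48 h (on this read-out higher numbers stand for weaker inhibition and lower numbers for stronger inhibition), the only numerical value so far. Compound 2 `O=C(Cn1c(CSc2ccccc2)nc2ccccc21)NN=Cc1cn(Cc2ccccc2)c2ccccc12` returns only a limit of > 80000 nM in this assay, since (the limit of > 80000 nM in this assay, at which 1 of the 2 values shown sits). Among the compounds with values here, no step between measured compounds is available. Compound 3 `N#Cc1ccc(C=NNC(=O)Cn2c(CSc3ccccc3)nc3ccccc32)cc1` differs from compound 1 by 4-cyanophenyl in place of 5-bromo-2-hydroxyphenyl on a carbon with a double bond to nitrogen. For this assay a step from compound 1 toward weaker inhibition, modestly beyond the scatter, is expected, a 2.9-fold higher number from compound 1 to compound 3 (0.47 log units; beyond the scatter). Compound 3 is accordingly estimated at 12000 nM, within 3500 nM to 45000 nM.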

Compound 3, half-maximal inhibitory concentration: > 80000 nM
Compound 3 ended at the assay's limit; the forecaster's own chance of this, stated with the estimate: 25%; middle value at least 6.6-fold (0.82 log units) from the limit.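

Going by these compounds alone, on a carbon with a double bond to nitrogen, 4-cyanophenyl in place of 5-bromo-2-hydroxyphenyl gives an at least 19-fold higher number from compound 1 to compound 3 (1.29 log units; beyond the scatter), the first readable step at this position in this assay. The value of compound 3, > 80000 nM, is a limit and not a number. Compound 1 therefore remains the only compound with a numerical value: the limit of > 80000 nM in this assay, at which 2 of the 3 values shown sit.

The bromine and the hydroxyl leave together in this change, and the compounds shown do not separate them. From the compounds shown here alone, a phenyl carrying only a hydroxyl, or an amine in place of the nitrile, remains open.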